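The compounds below may be only part of what the source reports. "The series", "measured", "known", "first", "only" and "open" are said of these compounds alone.

Two compounds of the series carry a result so far. For the measured compounds named here, compound 1 `CCc1nc(-c2cccc(F)c2)c(C(=O)N2CCN(c3cccc(OC)c3)CC2)o1` is the only member with a number: in a functional assay on HL-60 cells (Homo sapiens) for inhibition, read by MTT assay, with a stated time of 72 h (on this read-out lower numbers stand for stronger inhibition and higher numbers for weaker inhibition), compound 1 gives 201 nM, which places it alone at the head of what is known. Going by the values given here, compound 2 `COc1ccc(-c2nc(C)oc2C(=O)N2CCN(c3cccc(Cl)c3)CC2)cc1` differs from compound 1 in more than one place, so no single step is drawn from it; in this assay compound 2 gives "not active" (no number reported), a verdict without a number behind it. Compound 3 `COc1cccc(N2CCN(C(=O)c3oc(C(F)(F)F)nc3-c3cccc(F)c3)CC2)c1` is the next to be measured. It differs from compound 1 in one place: trifluoromethyl in place of ethyl on an aromatic carbon. Among the compounds with values here, no measured pair shows the effect of such an exchange on the five-membered aromatic ring of the shared core. On that basis a step of modest size is expected in this assay, with weakening somewhat more likely than gain, and the estimated step is a 1.6-fold higher number from compound 1 to compound 3 (0.20 log units; within the scatter). Compound 3 is therefore expected to give 320 nM in this assay, within 100 nM to 1000 nM.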

Compound 3, half-maximal inhibitory concentration: "not active" (no number reported)
The entry for compound 3 holds no number; the estimate stays without a comparison.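

In this assay, for the compounds shown here, compound 3 carries no number, only a verdict of not active, so no step from compound 1 to compound 3 can be read. From the compounds shown here alone, the size of the change with trifluoromethyl in place of ethyl stays open. No measurement shown bears on the reason for this result.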